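The source may hold more compounds than are shown below. What is called first, only, known or untested is meant among the compounds shown, and "the series" means these compounds.

Compound 1 `C=C1[C@H](C)CCC[C@]1(C)CC/C(C)=C/CC1=C(O)C(=O)C=C(N[C@@H](C(=O)O)[C@H](C)O)C1=O`: > 10 ug/mL
Compound 2 `COC1=CC(=O)C(O)=C(C/C=C(\C)CC[C@@]2(C)CCC=C(C)[C@H]2C)C1=O`: > 10 ug/mL

Both entries are limits, not numbers, in an ADME assay on KB cells (Homo sapiens) for cytotoxicity, with a stated time of 48 h; on this read-out higher numbers stand for weaker inhibition and lower numbers for stronger inhibition. Compound 2 stands at > 10 ug/mL, which is a limit. Within the data shown here, the only evidence so far is the limit of > 10 ug/mL in this assay, at which 2 of the 2 values shown sit.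

Compound 3 `CC1=CCC[C@](C)(CC/C(C)=C/CC2=C(O)C(=O)C=C(N[C@@H](C(=O)O)[C@H](C)O)C2=O)[C@@H]1C` has (1-carboxy-2-hydroxypropyl)amino in place of methoxy on a double-bonded ring carbon.

Among the measured compounds shown here, no measured step is available to size this change. The expected a number no higher from compound 2 to compound 3 (the limit leaves the size open) in this assay means no move beyond the scatter in either direction, resting on (the limit of > 10 ug/mL in this assay, at which 2 of the 2 values shown sit). Compound 3 is estimated at 10 ug/mL, with an expected range of 5 ug/mL to 20 ug/mL.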

Compound 3, half-maximal inhibitory concentration: > 10 ug/mL
Compound 3: a limit, no number (the forecaster's own chance of this, stated with the estimate: 85%); the middle value sits exactly at the limit.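

Among these compounds, no step among compound 1, compound 2 and compound 3 can be read: all three entries in this assay are limits, not numbers. From the compounds shown here alone, whether (1-carboxy-2-hydroxypropyl)amino in place of methoxy changes the read-out at all stays open.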